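Working notes: quinolin-3-yl for pyridin-4-yl at the arm

The source may report more compounds than this note shows. Statements on the series, on what has been measured and on what is new or still open speak of the compounds shown alone.

Measured so far:
compound 1 `N#Cc1ccc(CNc2ccc(-c3c(N)nc(N)nc3COCc3ccccc3)cc2)cc1`: 19 nM
compound 2 `Nc1nc(N)c(-c2ccc(NCc3ccncc3)cc2)c(COCc2ccccc2)n1`: 86 nM

In a functional assay on CHOK cells for antagonist activity at growth hormone secretagogue receptor type 1 (Homo sapiens), read by calcium flux (on this read-out higher numbers stand for weaker inhibition and lower numbers for stronger inhibition), compound 1 gives 19 nM and compound 2 gives 86 nM. Compound 2 thus carries the higher of the two numbers; the gap is a 4.5-fold higher number from compound 1 to compound 2 (0.66 log units; beyond the scatter), a modest step beyond the scatter. Compound 3 `Nc1nc(N)c(-c2ccc(NCc3cnc4ccccc4c3)cc2)c(COCc2ccccc2)n1` is not yet measured. It differs from compound 2 by quinolin-3-yl in place of pyridin-4-yl on a saturated chain carbon bound to a nitrogen on an aromatic ring. Among the compounds with values here, the only measured step that bears on this position is the one from compound 1 to compound 2, which shows that the arm set on the saturated chain carbon bound to the ring nitrogen moves the number by a modest amount in either direction. Compound 3 is therefore expected to move back toward the number of compound 1, by an expected step of a 2.2-fold lower number from compound 2 to compound 3 (0.33 log units; beyond the scatter). The estimate for compound 3 is 40 nM, with an expected range of 10 nM to 160 nM.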

Compound 3, half-maximal inhibitory concentration: 780 nM
Beside the measured number, compound 3's estimate is 20-fold (1.29 log units) below it; measured number outside the range, above it.
By their numbers in this assay, from the lowest: compound 1; then compound 2; then compound 3.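

In this assay the arm on a saturated chain carbon bound to a nitrogen on an aromatic ring proves less forgiving than the earlier pair suggested: quinolin-3-yl in place of pyridin-4-yl gives a 9.1-fold higher number from compound 2 to compound 3 (0.96 log units; beyond the scatter) and, set against 4-cyanophenyl, a 41-fold higher number from compound 1 to compound 3 (1.61 log units; beyond the scatter) on the same arm. The change adds a six-membered aromatic ring of carbon only while keeping one hydrogen-bond acceptor and no net charge, so in this pair a matching acceptor count does not hold the number. Nothing at hand accounts for this loss.

Open, from the compounds shown here alone, is whether the loss follows the added carbon ring or the changed setting of the ring nitrogen. A pyridin-3-yl arm and a naphthalen-2-yl arm on the same chain carbon would separate the two.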